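The source may report more compounds than this note shows. Statements on the series, on what has been measured and on what is new or still open speak of the compounds shown alone.

Working notes. In a functional assay on HepG2 cells (Homo sapiens) for antiproliferative activity, read by CCK-8 assay, with a stated time of 72 h (on this read-out higher numbers stand for weaker inhibition and lower numbers for stronger inhibition), compound 1 `Cc1nc(C)c(/C=C/C(=O)c2ccc(NC(=O)c3ccccc3)cc2)nc1C` gives 1310 nM, the lowest of the three numbers recorded. Compound 3 `Cc1nc(C)c(/C=C/C(=O)c2ccc(NC(=O)c3ccc(F)cc3F)cc2)nc1C` gives 2990 nM. Compound 2 `COc1cc(C(=O)Nc2ccc(C(=O)/C=C/c3nc(C)c(C)nc3C)cc2)cc(OC)c1OC` also differs from compound 1 on the benzoyl ring, and compound 2 gives 4860 nM. Among the measured compounds shown here, the one single-point step recorded is a 2.3-fold higher number from compound 1 to compound 3 (0.36 log units; beyond the scatter). Compound 4 `COc1ccc(C(=O)Nc2ccc(C(=O)/C=C/c3nc(C)c(C)nc3C)cc2)cc1` differs from compound 1 by methoxy in place of hydrogen on an aromatic carbon. For the measured compounds named here, no measured step covers a methoxy at this position directly; the difluoro step on the same ring went upward, and compound 2 sits higher still. A modest upward step is therefore expected, a 1.9-fold higher number from compound 1 to compound 4 (0.28 log units; within the scatter). For compound 4 the estimate is 2500 nM, within a range of 1200 nM to 5500 nM.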

Compound 4, half-maximal inhibitory concentration: 1190 nM
Beside the measured number, compound 4's estimate is 2.1-fold (0.32 log units) above it; the measured number lies below the stated range.
By their numbers in this assay, from the lowest: compounds 4 and 1 (each within the scatter of the next); then compounds 3 and 2 (each within the scatter of the next).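

Methoxy on the aromatic carbon para to a large group leaves the number level in this assay, with a 1.1-fold lower number from compound 1 to compound 4 (0.04 log units; within the scatter), so this ring takes a substituent here without a step beyond the scatter. The substituents on this ring do not act alike: a 2.5-fold lower number from compound 3 to compound 4 (0.40 log units; beyond the scatter), which separates 4-methoxyphenyl from 2,4-difluorophenyl. No measurement at hand explains this difference. On these data alone, whether an amine or a carboxylic acid at this position would also leave the number level stays open. So does whether a longer alkoxy chain would do so.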